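This account rests on a few compounds, and the source may have more. Where it says the series, first, only, none or still open, it means among the compounds named here.

Measured compounds:
- Compound 1, `CCc1cc2c(cc1C(=O)c1ccc(C(=O)O)cc1)C(C)(C)CCC2(C)C`, in an assay on isolated protein for binding affinity to retinoic acid receptor beta (Homo sapiens) (a lower number here means tighter binding, a higher number weaker binding), compound 1 gives > 1000 nM, which is a limit of the assay rather than a number.
- Compound 2, `CCCc1cc2c(cc1C(=O)c1ccc(C(=O)O)cc1)C(C)(C)CCC2(C)C`, in this assay compound 2 gives > 1000 nM, again a limit and not a number.

The two share a core and differ only in the chain on the aromatic ring. The step that the two limits leave unreadable from compound 1 to compound 2 cannot be read, since both ends sit at the limit of > 1000 nM in this assay, at which 2 of the 2 values shown sit. Compound 2 therefore stands only at a limit, with nothing to set it apart from compound 1.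

Compound 3, `CC1(C)CCC(C)(C)c2cc(C(=O)c3ccc(C(=O)O)cc3)c(F)cc21`, differs from compound 2 in one place: fluoro in place of propyl on an aromatic carbon. Fluoro takes the place of propyl on the same aromatic carbon, ortho to the large group, meta to the fused ring and para to the fused ring.

For the measured compounds named here, the only measured step bears on a chain carbon and is unreadable, so it gives no size to carry over. Nothing in the data points to a gain in binding, and both neighbours of compound 3 sit at the limit; the step that the limit leaves unreadable from compound 2 to compound 3 is thus expected to leave compound 3 weak as well. Compound 3 is estimated at 3000 nM, with a range from 400 nM to 30000 nM.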

Compound 3, dissociation constant: > 1000 nM
Compound 3: a limit, no number (the forecaster's own chance of this, stated with the estimate: 70%); the middle value does not contradict the limit.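

In this assay compound 3 gives > 1000 nM, a limit of the assay and not a number. For the compounds shown here, no step among compound 1, compound 2 and compound 3 can be read: the limit of > 1000 nM in this assay, at which 3 of the 3 values shown sit. The compounds shown leave open how tightly any of the three binds, and whether ethyl, propyl or fluoro at this aromatic carbon makes any difference.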